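Pyridin-3-yl in Place of Phenyl in a Weak Antiproliferative Series

The source may report more compounds than this note shows. Statements on the series, on what has been measured and on what is new or still open speak of the compounds shown alone.

Compound 1 `CCN(c1ccc(C#N)c(Cl)c1)c1cc(-c2cccs2)ccc1C`: 22000 nM
Compound 2 `CCN(c1ccc(C#N)c(Cl)c1)c1cc(-c2ccccc2)ccc1C`: > 30000 nM (a limit)

In a functional assay on CWR22R cells (Homo sapiens) for antiproliferative activity, read by CCK-8 assay, with a stated time of 6 days (on this read-out higher numbers stand for weaker inhibition and lower numbers for stronger inhibition), compound 1 gives 22000 nM. For compound 2 the assay reports only a limit, > 30000 nM. As far as these compounds go, the step of an at least 1.3-fold higher number from compound 1 to compound 2 (0.13 log units; that floor lies within the scatter) thus has only a floor, and compound 2 sits at the limit (the limit of > 30000 nM in this assay, at which 1 of the 2 values shown sits), so its exact value is unknown. Compound 3 `CCN(c1ccc(C#N)c(Cl)c1)c1cc(-c2cccnc2)ccc1C` differs from compound 2 by pyridin-3-yl in place of phenyl on an aromatic carbon. Going by the values given here, no measured step involves a pyridin-3-yl group, so none bears directly on this change, and the single measured step is capped. I expect no change beyond the scatter. Compound 3 is estimated at 30000 nM, between 10000 nM and 90000 nM, an expected step of a number no higher from compound 2 to compound 3 (the limit leaves the size open).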

Compound 3, half-maximal inhibitory concentration: 2000 nM
Estimate against measurement, compound 3: 15-fold (1.18 log units) above; measured number below the stated range.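

In this assay, the two earlier compounds gave no sign that changing the ring on this aromatic carbon could move the number beyond the scatter, but pyridin-3-yl does so against both earlier rings. Pyridin-3-yl in place of phenyl gives an at least 15-fold lower number from compound 2 to compound 3 (1.17 log units; beyond the scatter), and pyridin-3-yl in place of thiophen-2-yl gives an 11-fold lower number from compound 1 to compound 3 (1.04 log units; beyond the scatter). The first step has only a floor, since the value for compound 2 is a limit: the limit of > 30000 nM in this assay, at which 1 of the 3 values shown sits.

Why pyridin-3-yl has this effect stays open. So does how pyridin-4-yl or pyridin-2-yl would compare at this position.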